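A reversed amide with a cyclopentyl ring replaces the morpholine hydrazide

The source may report more compounds than this note shows. Statements on the series, on what has been measured and on what is new or still open speak of the compounds shown alone.

Three compounds share a core in which a substituted benzyl group sits on a five-membered aromatic ring, and they were tested in an assay on CHO-K1 cells for displacement of a labelled ligand from prostaglandin E2 receptor EP1 subtype (Homo sapiens); on this read-out higher numbers stand for weaker inhibition and lower numbers for stronger inhibition. Compound 1 `Cc1cc(C(=O)NN2CCOCC2)nn1Cc1cc(Cl)ccc1OCC(C)C` gives 251 nM. Compound 2 `Cc1cc(NC(=O)CC2CCCCC2)nn1Cc1cc(Cl)ccc1OCc1ccccc1` gives 6.31 nM, and compound 3 `Cc1cc(NC(=O)C2CCCO2)nn1Cc1cc(Cl)ccc1OCc1ccccc1` gives 39.8 nM. Compound 1 therefore stands with the highest number of the three, while compound 2 stands with the lowest.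

Compound 4 `Cc1cc(NC(=O)C2CCCC2)nn1Cc1cc(Cl)ccc1OCC(C)C` has not been measured. Against compound 1 it differs in one place: (cyclopentylcarbonyl)amino in place of (morpholin-4-yl)carbamoyl on an aromatic carbon. This is a larger alteration than any measured step, since both the direction of the amide link and the ring attached to it change at once.

Among the measured compounds shown here, the one measured step that bears on it is a 6.3-fold higher number from compound 2 to compound 3 (0.80 log units; beyond the scatter), which shows that the ring on the carbonyl carbon of the amide can move the number well beyond the scatter. Compounds 2 and 3 also carry a benzyloxy group where compound 1 and compound 4 carry an isobutoxy group, so no exact match exists; still, both compounds with an acylamino group on the aromatic carbon give markedly lower numbers than compound 1.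

A clearly lower number is therefore expected for compound 4, a step of a 10-fold lower number from compound 1 to compound 4 (1.00 log units; beyond the scatter), giving an estimate of 25 nM with a range from 5 nM to 125 nM.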

Compound 4, half-maximal inhibitory concentration: 25.1 nM
The estimate for compound 4 lay 1.0-fold (0.00 log units) below the measured number; the range from low to high includes it.
By their numbers in this assay, from the lowest: compound 2; then compounds 4 and 3 (each within the scatter of the next); then compound 1.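

Compounds 2 and 3 varied only the ring on the carbonyl carbon, so they could not show what the group on the aromatic carbon does by itself. Compounds 1 and 4 supply that comparison: with the isobutoxy group and the rest of the shared core unchanged, (cyclopentylcarbonyl)amino in place of (morpholin-4-yl)carbamoyl gives a 10-fold lower number from compound 1 to compound 4 (1.00 log units; beyond the scatter) in this assay, so this position can move the number beyond the scatter even when the other side of the molecule stays fixed. This single swap changes both the direction of the amide link and the ring it carries, and no measurement shown here explains the step.

No pair among the compounds shown separates the direction of the amide link from the identity of the ring, so it remains open which of the two accounts for the step. Also open, on these data alone, is how the number would respond with the isobutoxy group kept and a morpholine ring, a longer carbon chain or a carboxylic acid attached to the carbonyl carbon of the acylamino group.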